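A few compounds are considered here, and "the series" means these few. Any claim that something is new, unique, unknown or untested is made for them only; others in the source may bear on it.

Of the compounds shown here, three have been measured in a physicochemical assay for lipophilicity, at pH 7.4; on this read-out higher numbers stand for higher lipophilicity and lower numbers for lower lipophilicity. Compound 1 `CNC(=O)c1ccc(=O)n(Cc2cc(Br)ccc2F)c1` gives 2.6, compound 2 `CNC(=O)c1cc(C(=O)NC2CC2)cn(Cc2ccc3nc[nH]c3c2)c1=O` gives 1.2, and compound 3 `CNC(=O)c1cc(C(=O)NCCC(C)C)cn(Cc2ccccc2)c1=O` gives 4.8. Compound 2 thus sits lowest of the three, with compound 1 nearest and compound 3 furthest, both beyond the scatter.

Compound 4 `CNC(=O)c1cc(C(=O)NC2CC2)cn(Cc2ccc(C)cc2)c1=O` has not been measured. It differs from compound 2 in one place: 4-methylphenyl in place of 1H-benzimidazol-6-yl on a saturated chain carbon bound to an aromatic nitrogen. The group that leaves carries a hydrogen-bond donor and acceptor, the one that enters carries none. In this assay an upward step is expected, a number 1.80 log units higher from compound 2 to compound 4 (beyond the scatter), because compound 2 stands at 1.2 while compound 3, whose ring on that carbon also lacks such atoms, stands at 4.8. For compound 4 the expected value is 3, between 2.4 and 3.6.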

Compound 4, distribution coefficient: 3.5
The estimate for compound 4 lay 0.50 log units below the measured number; low and high end bracket the measured number.
By their numbers in this assay, from the lowest: compound 2; then compound 1; then compound 4; then compound 3.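

In this assay, among these compounds, the swap of 1H-benzimidazol-6-yl for 4-methylphenyl, on a saturated chain carbon bound to an aromatic nitrogen, gives a number 2.30 log units higher from compound 2 to compound 4 (beyond the scatter) and is the first change here confined to one place. The earlier compounds shown here differed in more than one place, so they could not show how far this position alone can move the number. Nothing available explains the size of this step.

Open, from the compounds shown here alone, is where a pyridin-4-yl or 4-aminophenyl group on this carbon would stand with the rest of compound 2 kept. Also open, going by these compounds, is whether a similar step would appear with the other amide of compound 3.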